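A few compounds are considered here, and "the series" means these few. Any claim that something is new, unique, unknown or untested is made for them only; others in the source may bear on it.

Compound 1 `Cc1ccsc1CN(C(=O)Nc1cccc(C#N)c1)n1cnnc1` was tested in a functional assay on B16-F10 cells (Mus musculus) for cytotoxicity, read by MTT assay, with a stated time of 48 h (on this read-out lower numbers stand for stronger inhibition and higher numbers for weaker inhibition), where compound 1 gives 28900 nM. Compound 2 `CC1CCC(NC(=O)N(Cc2ccccn2)n2cnnc2)CC1` was run the same way, and in this assay compound 2 gives 39700 nM. Compound 1 stands at the lower of the two numbers, but its difference from compound 2 lies within the scatter of repeated measurements, so nothing separates them. Compound 3 `Cc1ccsc1CN(C(=O)Nc1cccc(Cl)c1)n1cnnc1` has not yet been measured. It differs from compound 1 in one place: chloro in place of cyano on an aromatic carbon. The chloro group enters where the cyano group leaves, on an aromatic carbon of a six-membered aromatic ring of carbon only. Going by the values given here, no pair of measured compounds shows this change, so the measured values say nothing about its size. Compound 3 is expected to show a step of a 1.2-fold lower number from compound 1 to compound 3 (0.06 log units; within the scatter), none beyond the scatter. Compound 3 is expected to give 25000 nM in this assay, with a range from 10000 nM to 60000 nM.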

Compound 3, half-maximal inhibitory concentration: > 50000 nM
Compound 3: only a limit was reported; the forecaster's own chance of this, stated with the estimate: 10%; middle value at least 2.0-fold (0.30 log units) from the limit.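

In this assay compound 3 is reported only as a limit, > 50000 nM, and not as a number. On this aromatic carbon, meta to a large group, 3-cyanophenyl to 3-chlorophenyl gives an at least 1.7-fold higher number from compound 1 to compound 3 (0.23 log units; that floor lies within the scatter), so this one example shows that chloro in place of cyano brings no lower number, although the floor of the step does not establish a loss. The full size of the step stays unfixed, and the reading ends at a limit: the limit of > 50000 nM in this assay, at which 1 of the 3 values shown sits.

The compounds shown leave open how an amine or a methoxy group on this same carbon would read against the cyano group of compound 1. They also leave open whether the chloro-for-cyano change would behave the same way on a different core.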